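Imidazolyl for carbamoylphenyl: expected cytotoxicity of compound 4

The compounds below may be only part of what the source reports. "The series", "measured", "known", "first", "only" and "open" are said of these compounds alone.

Measured compounds:
compound 1, `CN(c1ccc(OC(F)(F)F)cc1)c1cc(-c2ccncc2)ncn1`: > 10000 nM
compound 2, `NC(=O)c1ccccc1-c1cc(Nc2ccc(OC(F)(F)F)cc2)ncn1`: > 10000 nM
compound 3, `Fc1ccc(Nc2cc(-c3ccncc3)ncn2)cc1`: > 10000 nM

In an ADME assay on BaF3 cells (Mus musculus) for cytotoxicity (a higher number here means that more compound is needed for the effect, a lower number that less compound is needed), compound 1 gives > 10000 nM, which is a limit of the assay and not a number. Compound 2 gives > 10000 nM in this assay, again a limit. Compound 3 gives > 10000 nM in this assay, also a limit. Compound 2 therefore stands with the other two at the limit of > 10000 nM in this assay, at which 3 of the 3 values shown sit; no compound shown gives a number.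

Compound 4, `FC(F)(F)Oc1ccc(Nc2cc(-n3ccnc3)ncn2)cc1`, differs from compound 2 by 1H-imidazol-1-yl in place of 2-carbamoylphenyl on an aromatic carbon.

Within the data shown here, as no measured step is available, the change is expected to produce no step beyond the scatter, and the step from compound 2 to compound 4 is estimated as a step that the limit leaves unreadable from compound 2 to compound 4. Compound 4 is expected to give about 20000 nM in this assay, within a range of 5000 nM to 80000 nM.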

Compound 4, half-maximal effective concentration: > 10000 nM
Compound 4 ended at the assay's limit (the forecaster's own chance of this, stated with the estimate: 85%); the middle value lies beyond the limit too.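

In this assay compound 4 gives > 10000 nM, which is a limit and not a number. Among these compounds, compound 2 stands at the same limit, so no step between compound 2 and compound 4 can be read. The compounds shown leave open whether 1H-imidazol-1-yl in place of 2-carbamoylphenyl changes the concentration needed for the effect.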